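The compounds below may be only part of what the source reports. "The series", "measured", "known", "first", "only" and "open" are said of these compounds alone.

Compound 1 `CCC[C@H](CCn1cncn1)c1ccc(C)cc1` gives 47.2 ug/mL.
Compound 2 `CCCC[C@H](CCn1cncn1)c1ccc(C)cc1` gives 26.5 ug/mL.
Compound 3 `CCCC[C@@H](CCn1cncn1)c1ccc(C)cc1` gives 56.5 ug/mL.

All three numbers come from an ADME assay on RD cells (Homo sapiens) for cytotoxicity, read by MTT assay, with a stated time of 3 days; on this read-out higher numbers stand for lower toxicity in this test and lower numbers for higher toxicity in this test. Compound 2 has the lowest of the three. Its nearest neighbour is compound 1, at a 1.8-fold lower number from compound 1 to compound 2 (0.25 log units; within the scatter), a gap within the scatter, while the larger gap is a 2.1-fold higher number from compound 2 to compound 3 (0.33 log units; beyond the scatter); that pair differs only in configuration as drawn (the fact that compounds 2 and 3 differ only in the configuration as drawn), and tells nothing about the chain itself.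

Compound 4 `Cc1ccc([C@@H](CCn2cncn2)Cc2ccccc2)cc1` is compound 2 altered at the chain: phenyl in place of propyl on a saturated chain carbon, two bonds along the chain from an aromatic carbon. Among the measured compounds shown here, of the measured steps, only the one from compound 1 to compound 2 touches the same chain, and it amounted to a 1.8-fold lower number from compound 1 to compound 2 (0.25 log units; within the scatter) for methyl in place of hydrogen. For the measured compounds named here, the change to compound 4 is larger than that, and no measured pair puts an aromatic ring at this place, leaving the direction uncertain. For compound 4 the expected step in this assay is a 1.3-fold lower number from compound 2 to compound 4 (0.12 log units; within the scatter), a modest lowering with wide allowance either way. Compound 4 is accordingly estimated at 20 ug/mL, between 8 ug/mL and 50 ug/mL.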

Compound 4, half-maximal cytotoxic concentration: 109 ug/mL
Compound 4: middle estimate off by 5.5-fold (0.74 log units), on the low side, and the stated range ends below it.
By their numbers in this assay, from the lowest: compounds 2, 1, 3 and 4 (each within the scatter of the next, the first and the last beyond it).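

With phenyl in place of propyl, the chain position gives a clear move in this assay: a 4.1-fold higher number from compound 2 to compound 4 (0.61 log units; beyond the scatter), and the comparison with the shorter chain points the same way, a 2.3-fold higher number from compound 1 to compound 4 (0.36 log units; beyond the scatter), both towards lower toxicity in this test. The earlier chain step, a 1.8-fold lower number from compound 1 to compound 2 (0.25 log units; within the scatter), had stayed within the scatter, so the compounds with plain alkyl chains gave no sign that a change at this carbon could lift the number past compound 1 by a readable margin; an aromatic ring at this place does so, and the same difference can be read as butyl to benzyl. Nothing in hand accounts for the size or direction of this rise.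

The compounds shown leave open whether the phenyl ring as such matters, which a saturated cyclohexyl at the same place would test, and whether the number holds once an amine or a carboxylic acid is carried on that ring. Also open, as far as these compounds go, is how the opposite configuration of compound 4 would read, given that configuration alone gave a 2.1-fold higher number from compound 2 to compound 3 (0.33 log units; beyond the scatter).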